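Swapping the benzyl of compound 2 for a furan ring

This account rests on a few compounds, and the source may have more. Where it says the series, first, only, none or still open, it means among the compounds named here.

Measured compounds:
compound 1 `CCOC(=O)c1ccc(-c2nn(Cc3cccc(Cl)c3)c3ccccc23)cc1`: 80 nM
compound 2 `CCOC(=O)c1ccc(-c2nn(Cc3ccccc3OC)c3ccccc23)cc1`: 470 nM

In a functional assay on cells (Platelet, Homo sapiens) for inhibition (on this read-out higher numbers stand for weaker inhibition and lower numbers for stronger inhibition), compound 2 stands highest of the two numbers, with compound 1 the nearer at a lower value. Compound 3 `CCOC(=O)c1ccc(-c2nn(-c3ccco3)c3ccccc23)cc1` differs from compound 2 by furan-2-yl in place of 2-methoxybenzyl on an aromatic nitrogen. Among the measured compounds shown here, the only measured step, a 5.9-fold higher number from compound 1 to compound 2 (0.77 log units; beyond the scatter), exchanged one aryl group for another on the saturated carbon and so does not speak to removing that carbon. The expected step is therefore uncertain, with a modest rise judged most likely: a 1.5-fold higher number from compound 2 to compound 3 (0.17 log units; within the scatter). Compound 3 is estimated at 700 nM, within 150 nM to 3000 nM.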

Compound 3, half-maximal inhibitory concentration: 340 nM
Estimate against measurement, compound 3: 2.1-fold (0.31 log units) above; low and high end bracket the measured number.
By their numbers in this assay, from the lowest: compound 1; then compounds 3 and 2 (each within the scatter of the next).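

In this assay, furan-2-yl on the aromatic nitrogen takes the place of 2-methoxybenzyl, dropping the saturated chain carbon and going from 9 to 5 heavy atoms, with a 1.4-fold lower number from compound 2 to compound 3 (0.14 log units; within the scatter). Set against the 3-chlorobenzyl group, the same furan-2-yl gives a 4.3-fold higher number from compound 1 to compound 3 (0.63 log units; beyond the scatter), so 3-chlorobenzyl remains the best of the three groups at this position. Nothing available explains these steps. As far as these compounds go, what a phenyl group or a furan-2-ylmethyl group on this nitrogen would give remains open, and with it whether the chain carbon and the ring type matter separately.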